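Methoxy-to-dimethylamino exchange on the aryl substituent

A few compounds are considered here, and "the series" means these few. Any claim that something is new, unique, unknown or untested is made for them only; others in the source may bear on it.

Three compounds in this series have numbers from a functional assay, with a stated time of 20 min; a lower number here means a stronger inhibitor, a higher number a weaker inhibitor. Compound 1 `COc1ccc(-c2nc(NN)n(C)c(=O)c2C#N)cc1` gives 41 ug/mL in this assay. Compound 2 `CCOC(=O)c1cnn(-c2nc(-c3ccc(OC)cc3)c(C#N)c(=O)n2C)c1N` gives 59 ug/mL in this assay. Compound 3 `CSc1nc(-c2ccco2)c(C#N)c(=O)n1C` gives 68 ug/mL in this assay. On these numbers compound 2 sits in the middle of the three; its gap to compound 3 is within the usual scatter of this assay, and so is its gap to compound 1, so none of the three can be set apart from the others on this evidence.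

Compound 4 `CCOC(=O)c1cnn(-c2nc(-c3ccc(N(C)C)cc3)c(C#N)c(=O)n2C)c1N` has not yet been measured in this assay. It differs from compound 2 in one place: dimethylamino in place of methoxy on an aromatic carbon. For the measured compounds named here, no pair of measured compounds shows what this exchange does, and the three measured compounds differ from one another in several places at once, so nothing in the numbers so far points in either direction for it.

The working expectation is therefore a step from compound 2 to compound 4 of a 1.1-fold lower number from compound 2 to compound 4 (0.03 log units; within the scatter) in this assay, that is, no change beyond the scatter. Compound 4 is accordingly estimated to give about 55 ug/mL in this assay, with a plausible range from 25 ug/mL to 120 ug/mL.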

Compound 4, half-maximal inhibitory concentration: 98 ug/mL
Compound 4: the middle estimate sits 1.8-fold (0.25 log units) below what was measured, within the range that was stated.
By their numbers in this assay, from the lowest: compounds 1, 2, 3 and 4 (each within the scatter of the next, the first and the last beyond it).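

In this assay, the exchange of 4-methoxyphenyl for 4-(dimethylamino)phenyl gives the series its first one-place comparison: a 1.7-fold higher number from compound 2 to compound 4 (0.22 log units; within the scatter). The step lies within the scatter, so on an aromatic carbon para to a large group, dimethylamino with its 3 heavy atoms stands in for methoxy with its 2 without a change that this assay can separate, at least on this single pair. No measurement accompanies these compounds that could speak to why the step has this size.

Going by these compounds, only these two groups have been compared in this place, so it remains open whether a carboxylic acid, a primary amine or a longer alkoxy chain there would move the number in this assay beyond the scatter. On these data alone, it also remains open whether the same methoxy-to-dimethylamino exchange would give a comparable step on the core of compound 1, where the rest of the molecule differs from compound 2, since a single pair cannot show whether the step carries over to other members.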